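A few compounds are considered here, and "the series" means these few. Any claim that something is new, unique, unknown or untested is made for them only; others in the source may bear on it.

Of the compounds shown here, two have so far been measured in a functional assay on U-87MG ATCC cells (Homo sapiens) for antiproliferative activity, read by MTT assay, with a stated time of 48 h; on this read-out higher numbers stand for weaker inhibition and lower numbers for stronger inhibition. Compound 1 `CC(=O)Nc1nc2ccc(-c3cnc(Cl)c(NS(=O)(=O)c4ccc(F)cc4)c3)cn2n1` gives 6950 nM in this assay. Compound 2 `COc1ncc(-c2ccc3nc(NC(=O)C4CC4)nn3c2)cc1NS(=O)(=O)c1ccc(F)cc1` gives 4850 nM in this assay, the lower of the two numbers, but the gap to compound 1 lies within the usual scatter of repeated measurements, so the two values do not truly separate the compounds. Among the compounds with values here, compound 1 and compound 2 differ from each other in more than one place, and no single step connects them.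

Compound 3 `O=C(Nc1nc2ccc(-c3cnc(Cl)c(NS(=O)(=O)c4ccc(F)cc4)c3)cn2n1)C1CC1` has not yet been measured in this assay. It differs from compound 2 in just one place: chloro in place of methoxy on an aromatic carbon. The chloro group that compound 3 carries at that place is the same group that compound 1 carries there, and the value of compound 1, 6950 nM, sits close to the value of compound 2. On this basis the step expected is a 1.1-fold higher number from compound 2 to compound 3 (0.05 log units; within the scatter), nothing beyond the scatter in either direction. Compound 3 is therefore estimated at 5500 nM in this assay, with a likely range from 2500 nM to 12000 nM.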

Compound 3, half-maximal inhibitory concentration: 11000 nM
Compound 3: the middle estimate sits 2.0-fold (0.30 log units) below what was measured; measured number inside the range.
By their numbers in this assay, from the lowest: compounds 2, 1 and 3 (each within the scatter of the next, the first and the last beyond it).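

Within the data shown here, with cyclopropyl held on the carbonyl carbon, chloro in place of methoxy on this aromatic carbon, next to the ring nitrogen, gives a 2.3-fold higher number from compound 2 to compound 3 (0.36 log units; beyond the scatter) in this assay and is the first single change here whose effect stands clear of the scatter, though only modestly. The other single change, cyclopropyl in place of methyl on the carbonyl carbon with chloro held fixed, gives a 1.6-fold higher number from compound 1 to compound 3 (0.20 log units; within the scatter) and so does not separate these two groups at that place. Nothing in the data available explains the step from methoxy to chloro.

As far as these compounds go, only methoxy and chloro appear at this aromatic carbon, so it remains open how a hydrogen, a fluoro group or an amino group would read there, and whether any of them would give a lower number than methoxy does. Methoxy is also seen only alongside cyclopropyl, which leaves open whether the same step would appear with methyl on the carbonyl carbon, or with a longer chain such as propyl.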